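The source may report more compounds than this note shows. Statements on the series, on what has been measured and on what is new or still open speak of the compounds shown alone.

Compound 1 `COc1cccc2cc(-c3ccccc3)c(O)nc12`: 10000 nM
Compound 2 `CCN(CC)C(=O)Cn1c(=O)c(-c2ccc(OC)cc2)cc2c(OC)cc(OC)cc21`: 10000 nM

Both values come from a functional assay on U-87MG ATCC cells for cytotoxicity against U-87 MG (Homo sapiens), read by colorimetric assay and MTT assay; a lower number here means a stronger inhibitor, a higher number a weaker inhibitor. Compound 2 stands level with compound 1 at the digits shown, so the two give no difference within the scatter, and neither can be ranked over the other. For the measured compounds named here, they also differ in more than one place, so they offer no measured step that isolates a single structural change.

Compound 3 `COc1ccc(-c2cc3c(OC)cc(OC)cc3n(CCC(=O)OCc3ccccc3)c2=O)cc1` has yet to be tested in this assay. It departs from compound 2 in the group on a saturated chain carbon bound to an aromatic nitrogen, where (benzyloxycarbonyl)methyl stands in place of diethylcarbamoyl: (benzyloxycarbonyl)methyl in place of diethylcarbamoyl on a saturated chain carbon bound to an aromatic nitrogen. Going by the values given here, no measured compound shows what this exchange does, so the expectation rests only on the two values in hand. With compound 2 at 10000 nM, the starting point offers no sign of activity to build on, and no step beyond the scatter is expected, in either direction. The expected change is a 1.1-fold lower number from compound 2 to compound 3 (0.05 log units; within the scatter). For compound 3 the estimated value is 9000 nM, with an expected range from 3000 nM to 20000 nM.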

Compound 3, half-maximal inhibitory concentration: 10000 nM
The estimate for compound 3 lay 1.1-fold (0.05 log units) below the measured number, within the range that was stated.
By their numbers in this assay, from the lowest: compounds 1, 2 and 3 (each within the scatter of the next).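

In this assay, for the compounds shown here, the exchange of diethylcarbamoyl for (benzyloxycarbonyl)methyl on a saturated chain carbon bound to an aromatic nitrogen is the first change in a single place that can be read, and it gives no change at the digits printed from compound 2 to compound 3 (within the scatter) in this comparison. Going by these compounds alone, the earlier pair differed in more than one place, so only this step ties a result to this position. Here, a group with a six-membered aromatic ring of carbon only replaces one with no ring, and the printed number stays the same, although this single exchange says nothing about other groups at this position. No supporting data bear on why the exchange leaves the number as it stands.

With all three compounds level at the digits printed, the compounds shown give no reference for a stronger inhibitor in this series. They leave open whether a carboxylic acid or a primary amine at the end of this chain, or a longer chain carrying either group, would move the number at all.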